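The source may report more compounds than this note shows. Statements on the series, on what has been measured and on what is new or still open speak of the compounds shown alone.

Compound 1 `COc1ccc(C(=O)/C=C/c2ccc(Br)cc2)c2c1C=CC(C)(C)O2` was tested in a functional assay on K562 cells (Homo sapiens) for antiproliferative activity, read by MTT assay, with a stated time of 24 h; a higher number here means a weaker inhibitor, a lower number a stronger inhibitor. In this assay compound 1 gives > 10000 nM, which is a limit of the assay and not a number. Compound 2 `COc1ccc(C(=O)/C=C/c2ccc(-c3ccccc3)cc2)c2c1C=CC(C)(C)O2` carries phenyl in place of bromo on an aromatic carbon. In this assay compound 2 gives > 10000 nM, again a limit rather than a number. Compound 3 `COc1ccc(C(=O)/C=C/c2ccc(-n3ccnc3)cc2)c2c1C=CC(C)(C)O2` carries 1H-imidazol-1-yl in place of bromo on an aromatic carbon. In this assay compound 3 gives > 10000 nM, also a limit. The steps a step that the two limits leave unreadable from compound 1 to compound 2, a step that the two limits leave unreadable from compound 1 to compound 3 and a step that the two limits leave unreadable from compound 2 to compound 3 carry no readable size because every value sits at the limit of > 10000 nM in this assay, at which 3 of the 3 values shown sit. Going by the values given here, compound 1 therefore stands at the limit, and no measured compound stands anywhere else.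

Compound 4 `COc1ccc(C(=O)/C=C/c2ccccn2)c2c1C=CC(C)(C)O2` differs from compound 1 by pyridin-2-yl in place of 4-bromophenyl on a double-bonded chain carbon bound to a double-bonded chain carbon. Among the compounds with values here, none of the measured steps covers this change, which exchanges the whole 4-bromophenyl rather than one substituent on it. Within the data shown here, the measured steps show only that exchanges on an aromatic carbon of compound 1 left every value at the limit. Compound 4 is therefore expected to sit at or near the limit as well, the step that the limit leaves unreadable from compound 1 to compound 4 being expected to be small and not readable in either direction. The estimate for compound 4 is 15000 nM, between 5000 nM and 50000 nM, most likely reported as a limit only.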

Compound 4, half-maximal inhibitory concentration: 5400 nM
Estimate against measurement, compound 4: 2.8-fold (0.44 log units) above, within the range that was stated.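

In this assay compound 4 is the only one of the four compounds shown to give a number and not a limit, at 5400 nM, so this place on a double-bonded chain carbon bound to a double-bonded chain carbon is the only one shown where a change yields a readable value. Putting pyridin-2-yl in place of 4-bromophenyl gives an at least 1.8-fold lower number from compound 1 to compound 4 (0.26 log units; that floor lies within the scatter), so only a floor on the step is known, and that floor does not on its own separate the two compounds beyond the usual scatter. The steps among compound 1, compound 2 and compound 3 cannot be read, and those three compounds stay at the limit: the limit of > 10000 nM in this assay, at which 3 of the 4 values shown sit.

As far as these compounds go, what stays open is whether the gain in a readable value follows from losing the bromine or from bringing in the ring nitrogen, a question that an unsubstituted phenyl, a pyridin-3-yl or a pyridin-4-yl at this same place would address. From the compounds shown here alone, it is also open how far the value of compound 4 would move with an amine or a methoxy group on the pyridine ring.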